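Methoxy to hydroxy on the 4-methoxyphenyl group

A few compounds are considered here, and "the series" means these few. Any claim that something is new, unique, unknown or untested is made for them only; others in the source may bear on it.

In a functional assay on MCF7 cells (Homo sapiens) for cytotoxicity, read by MTT assay, with a stated time of 72 h (on this read-out lower numbers stand for stronger inhibition and higher numbers for weaker inhibition), compound 1 (`COc1ccc(/C=C2\CCC/C(=C\c3cccc(Cl)c3)C2=O)cc1OC`) gives 6000 nM and compound 2 (`COc1ccc(/C=C2\CCC/C(=C\c3ccc(Br)cc3)C2=O)cc1OC`) gives 6900 nM and compound 3 (`COc1ccc(/C=C2\CCC/C(=C\c3ccc(OC)c(OC)c3)C2=O)cc1`) gives 7800 nM which places compound 3 within the scatter of both others.

Compound 4 (`COc1ccc(/C=C2\CCC/C(=C\c3ccc(O)cc3)C2=O)cc1OC`) differs from compound 3 by hydrogen in place of methyl on an oxygen on an aromatic ring so that 4-methoxyphenyl becomes 4-hydroxyphenyl.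

For the measured compounds named here, no measured compound carries this hydroxy group, so no measured step shows this exact change. The nearest evidence comes from swaps of the group on that same side: a 1.1-fold higher number from compound 2 to compound 3 (0.05 log units; within the scatter) and a 1.3-fold higher number from compound 1 to compound 3 (0.11 log units; within the scatter) and a 1.2-fold higher number from compound 1 to compound 2 (0.06 log units; within the scatter) are all within the scatter.

On that basis, the step of a 1.1-fold lower number from compound 3 to compound 4 (0.05 log units; within the scatter) is expected to stay within the scatter of this assay with no firm direction.

For compound 4 the estimated value is 7000 nM with an expected range from 3000 nM to 15000 nM in this series.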

Compound 4, half-maximal inhibitory concentration: 17000 nM
Compound 4: middle estimate off by 2.4-fold (0.39 log units), on the low side; measured number outside the range, above it.
By their numbers in this assay, from the lowest: compounds 1, 2 and 3 (each within the scatter of the next); then compound 4.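

In this assay, for the compounds shown here, swaps of this group had so far given no step beyond the scatter, but the hydroxy group does, the change from methyl to hydrogen on the oxygen giving a weaker number (a 2.2-fold higher number from compound 3 to compound 4 (0.34 log units; beyond the scatter)). The steps from the two halogen compounds point the same way (a 2.5-fold higher number from compound 2 to compound 4 (0.39 log units; beyond the scatter); a 2.8-fold higher number from compound 1 to compound 4 (0.45 log units; beyond the scatter)), so 4-hydroxyphenyl stands apart from 4-methoxyphenyl, 4-bromophenyl and 3-chlorophenyl, which remain within the scatter of one another. No measurement at hand accounts for this step.

As far as these compounds go, it remains open whether the step belongs to the hydroxy group itself or to any replacement of the methoxy group. An amine or a carboxylic acid in the same place, or a longer chain such as ethoxy, would help separate these two readings.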